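The source may hold more compounds than are shown below. What is called first, only, known or untested is meant among the compounds shown, and "the series" means these compounds.

Three compounds have been measured in an ADME assay on L132 cells (Homo sapiens) for cytotoxicity, read by MTT assay, with a stated time of 72 h; on this read-out lower numbers stand for stronger inhibition and higher numbers for weaker inhibition:
Compound 1, `COCOc1cc(C2=C(c3cc(OC)c(OC)c(OC)c3)C(=O)CC2O[SiH2]C(C)(C)C)ccc1OC`, gives 32 ug/mL.
Compound 2, `COc1ccc(C2=C(c3cc(OC)c(OC)c(OC)c3)CC(O)C2=O)cc1N`, gives 54 ug/mL.
Compound 3, `COc1ccc(C2=C(c3cc(OC)c(OC)c(OC)c3)C(=O)CC2OC(C)=O)cc1NC=O`, gives 2 ug/mL.

Among these three numbers compound 1 stands second highest. Its nearest neighbour is compound 2, whose number lies within the usual scatter of that of compound 1, so the two cannot be told apart on this read-out. Compound 3 stands furthest away, with a lower number, and its gap to compound 1 lies beyond the scatter, so compound 3 inhibits the cells more strongly than compound 1.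

The unmeasured compound 4, `COc1cc(C2=C(c3cc(C)c(OC)c(C)c3)C(O[SiH2]C(C)(C)C)CC2=O)cc(OC)c1OC`, is derived from compound 1 by a single change: 4-methoxy-3,5-dimethylphenyl in place of 4-methoxy-3-(methoxymethoxy)phenyl on a double-bonded ring carbon. The rest of the shared core is kept. Within the data shown here, no measured pair shows this change on its own, so there is nothing in the set to anchor its size or direction. Compound 2 and compound 3 each differ from compound 1 in several places at once, so the spread among them cannot be tied to any one change. The step from compound 1 to compound 4 in this assay is therefore expected to be small, as likely to go up as down, and the estimate places it within the scatter, a 1.1-fold lower number from compound 1 to compound 4 (0.06 log units; within the scatter). Compound 4 is expected to give 28 ug/mL, in a range from 9 ug/mL to 85 ug/mL.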

Compound 4, half-maximal inhibitory concentration: > 100 ug/mL
Compound 4: no number, only a limit (the forecaster's own chance of this, stated with the estimate: 15%); middle value at least 3.5-fold (0.55 log units) from the limit.
By their numbers in this assay, from the lowest: compound 3; then compounds 1 and 2 (each within the scatter of the next). At a limit, above all of these: compound 4.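

In this assay, among these compounds, replacing 4-methoxy-3-(methoxymethoxy)phenyl with 4-methoxy-3,5-dimethylphenyl on the double-bonded ring carbon is the first change that can be read on its own, and it gives an at least 3.1-fold higher number from compound 1 to compound 4 (0.49 log units; beyond the scatter). For compound 4 the read-out of > 100 ug/mL is a limit of the assay and not a number: the limit of > 100 ug/mL in this assay, at which 1 of the 4 values shown sits. The step shows that the aryl group at this position can shift the read-out beyond the scatter, towards weaker inhibition, with the rest of the shared core kept, which compound 2 and compound 3 could not show, as each differs from compound 1 in several places at once.

The swap removes the methoxymethoxy group and adds two methyl groups in a single step, so the compounds shown leave open which of these parts carries the shift. They also leave open how a hydroxyl group or a chlorine atom on this phenyl ring would read in this assay, and whether any group at this position would give a lower number than compound 1 does.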